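Swapping a difluorophenyl sulfone for a trifluoromethylphenyl sulfone

The source may report more compounds than this note shows. Statements on the series, on what has been measured and on what is new or still open speak of the compounds shown alone.

Compound 2 `O=C(NCc1ccc(S(=O)(=O)c2ccc(F)c(F)c2)cc1)c1cc2cnccc2[nH]1` gives the highest of the three readings in an ADME assay on microsomes from liver (Homo sapiens) for metabolic stability, read by LC-MS, with a stated time of 30 min, tested at 1 uM (a lower number here means that less of the compound is left, a higher number that more of the compound is left), namely 100%. Compound 3 `O=C(NCc1ccc(S(=O)(=O)c2ccccc2)cc1)c1nc2cnccc2[nH]1` comes nearest, as compound 3 gives 73% in this assay, a gap beyond the scatter. Compound 1 `O=C(NCc1ccc(S(=O)(=O)N2CCCCC2)cc1)c1cc2cnccc2s1` lies furthest away, as compound 1 gives 15% in this assay, again beyond the scatter. Compound 4 `O=C(NCc1ccc(S(=O)(=O)c2cccc(C(F)(F)F)c2)cc1)c1cc2cnccc2[nH]1` has not yet been tested in this assay; it differs from compound 2 in one place: 3-(trifluoromethyl)phenyl in place of 3,4-difluorophenyl on a sulfonyl sulfur. Among the compounds with values here, no pair of measured compounds differing in a single place is available, so this step has no measured precedent. A modest drop at most is expected, and the step is estimated as a number 12 percentage points lower from compound 2 to compound 4 (beyond the scatter). Compound 4 is therefore expected to give about 88% in this assay, with a likely range from 65% to 100%.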

Compound 4, percent of the compound remaining: 81%
The estimate for compound 4 lay 7 percentage points above the measured number, and the stated range covers the measured number.
By their numbers in this assay, from the lowest: compound 1; then compounds 3 and 4 (each within the scatter of the next); then compound 2.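

With 3-(trifluoromethyl)phenyl in place of 3,4-difluorophenyl on a sulfonyl sulfur, this assay gives a number 19 percentage points lower from compound 2 to compound 4 (beyond the scatter), the first single-place step available in this series. It shows that this position can take a different fluorinated aryl group at a modest cost in the amount of compound left. Nothing available explains the size of this step. On these data alone, it remains open how a morpholine or a pyridine ring would fare on the sulfonyl sulfur, and whether the same swap would give a similar step on the core of compound 3.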